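Swapping one aromatic amine substituent for another

The source may hold more compounds than are shown below. What is called first, only, known or untested is meant among the compounds shown, and "the series" means these compounds.

Of the compounds shown here, three built on one shared core have been measured in a functional assay on HeLa cells (Homo sapiens) for inhibition, read by sulforhodamine B assay; a lower number here means a stronger inhibitor, a higher number a weaker inhibitor. Compound 1 `Cc1ccc(NC2=CC(=O)c3nc4n(c3C2=O)[C@H]2OC[C@@H](O)[C@H]2OC4)cc1` gives 3860 nM. Compound 2 `O=C1C(NC2CC2)=CC(=O)c2c1nc1n2[C@H]2OC[C@@H](O)[C@H]2OC1` reaches only a limit of the assay, > 16000 nM, and not a number. Compound 3 `CCOc1ccccc1NC1=CC(=O)c2c(nc3n2[C@H]2OC[C@@H](O)[C@H]2OC3)C1=O` gives 8300 nM, the higher of the two numbers in hand, with compound 1 the nearer of the measured compounds.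

Among the compounds with values here, only one step between measured compounds has been computed: an at least 1.9-fold lower number from compound 2 to compound 3 (0.28 log units; that floor lies within the scatter). Because compound 2 sits at the limit of > 16000 nM in this assay, at which 1 of the 3 values shown sits, that step has only a floor, and the floor itself lies within the usual scatter, so its true size is open.

Compound 4 `CCc1ccc(NC2=CC(=O)c3c(nc4n3[C@H]3OC[C@@H](O)[C@H]3OC4)C2=O)cc1` has not yet been measured. It differs from compound 3 in one place: 4-ethylphenyl in place of 2-ethoxyphenyl on an amine nitrogen. Within the data shown here, no measured step exchanges one aromatic group for another on the amine nitrogen, so the single step in hand does not bear directly on this change. What compound 1 and compound 3 show is that two different aromatic groups on that nitrogen give numbers set apart by more than the scatter. The step of a 1.8-fold lower number from compound 3 to compound 4 (0.27 log units; within the scatter) is expected to be modest, toward a lower number. Compound 4 is therefore estimated at 4500 nM, within 2000 nM to 10000 nM.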

Compound 4, half-maximal inhibitory concentration: 6510 nM
Estimate against measurement, compound 4: 1.4-fold (0.16 log units) below, and the stated range covers the measured number.
By their numbers in this assay, from the lowest: compounds 1, 4 and 3 (each within the scatter of the next, the first and the last beyond it). At a limit, above all of these: compound 2.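

Within the data shown here, this is the first measured exchange of one aromatic group for another on the amine nitrogen. With 4-ethylphenyl in place of 2-ethoxyphenyl there is a 1.3-fold lower number from compound 3 to compound 4 (0.11 log units; within the scatter), so the two groups cannot be told apart here, even though the group that leaves carries a hydrogen-bond acceptor and the group that enters carries none. Replacing cyclopropyl with an aromatic group now gives a step that clears the scatter, an at least 2.4-fold lower number from compound 2 to compound 4 (0.39 log units; beyond the scatter), whereas the same comparison with compound 3 had a floor inside it, and this step too is only a floor, since compound 2 stands at a limit of the assay and not at a number: the limit of > 16000 nM in this assay, at which 1 of the 4 values shown sits.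

The compounds shown leave open whether a phenyl ring carrying a carboxylic acid or an amine, or a longer chain on the nitrogen in place of the ring, would give a number in the same range. Among these compounds, with cyclopropyl as the only non-aromatic group on that nitrogen, it also stays open whether the gap belongs to non-aromatic groups in general or to cyclopropyl alone.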